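The source may hold more compounds than are shown below. What is called first, only, known or untested is meant among the compounds shown, and "the series" means these compounds.

Three compounds have been measured in a functional assay on MCF7 cells (Homo sapiens) for inhibition, read by sulforhodamine B assay, with a stated time of 72 h; a higher number here means a weaker inhibitor, a lower number a stronger inhibitor:

compound 1 `COc1ccc2cc(C(C)c3nnc4n3N=C(c3ccc([N+](=O)[O-])cc3)CS4)ccc2c1` gives 18800 nM;
compound 2 `CC(C)Cc1ccc(C(C)c2nnc3n2N=C(c2ccc(Cl)cc2)CS3)cc1` gives 8800 nM;
compound 3 `CC(c1ccc(-c2ccccc2)c(F)c1)c1nnc2n1N=C(c1ccc(Cl)cc1)CS2` gives 8700 nM.

Compound 1 gives the highest of the three numbers and is thus the weakest inhibitor of the set; the values of compound 2 and compound 3 lie below it, and both gaps are beyond the usual scatter. Within the data shown here, compound 2 and compound 3 each carry a 4-chlorophenyl group on the shared core where compound 1 carries a 4-nitrophenyl group, but they also differ from compound 1 elsewhere, so no single step between measured compounds isolates that exchange.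

Compound 4 `COc1ccc2cc(C(C)c3nnc4n3N=C(c3ccc(Cl)cc3)CS4)ccc2c1` has not yet been measured in this assay. It differs from compound 1 in one place only: chloro in place of nitro on an aromatic carbon. Compound 2 at 8800 nM and compound 3 at 8700 nM both carry the chloro group and both sit below compound 1, which points the expectation downward. The expected step is therefore a modest one toward a stronger inhibitor, a 1.9-fold lower number from compound 1 to compound 4 (0.27 log units; within the scatter). Compound 4 is estimated at 10000 nM, within a range of 4000 nM to 25000 nM.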

Compound 4, half-maximal inhibitory concentration: 10100 nM
The estimate for compound 4 lay 1.0-fold (0.00 log units) below the measured number, within the range that was stated.
By their numbers in this assay, from the lowest: compounds 3, 2, 4 and 1 (each within the scatter of the next, the first and the last beyond it).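

Among these compounds, for the first time, a single pair isolates the exchange of 4-nitrophenyl for 4-chlorophenyl on the shared core, and in this assay it gives a 1.9-fold lower number from compound 1 to compound 4 (0.27 log units; within the scatter) with nothing else in the structure altered. At this place, on an aromatic carbon para to a large group, the single heavy atom of chloro therefore cannot be told apart from the 3 heavy atoms of nitro, although only nitro brings hydrogen-bond acceptors. Nothing measured here explains this small step.

The compounds shown leave open whether a different group at this place, such as an amine or a carboxylic acid, would move the number beyond the scatter. They also leave open whether the same exchange would read alike alongside the other side groups carried by compound 2 and compound 3.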